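Aryl swap on the amide benzyl group of the series

The source may report more compounds than this note shows. Statements on the series, on what has been measured and on what is new or still open speak of the compounds shown alone.

Measured so far:
compound 1 `Cc1cccc(Cc2n[nH]c3cc(O)c(C(=O)N(C)Cc4ccccc4)cc23)c1`: 490 nM
compound 2 `COc1ccc(CN(C)C(=O)c2cc3c(Cc4cccc(C)c4)n[nH]c3cc2O)cc1`: 540 nM

In a functional assay on A2780 cells (Homo sapiens) for antiproliferative activity, read by resazurin assay, with a stated time of 72 h (a higher number here means a weaker inhibitor, a lower number a stronger inhibitor), compound 1 gives 490 nM, and compound 2 gives 540 nM. Compound 2 carries the higher of the two numbers, but the step from compound 1 to it, a 1.1-fold higher number from compound 1 to compound 2 (0.04 log units; within the scatter), lies within the scatter, so no order between the two compounds can be read from these values.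

Compound 3 `Cc1cccc(Cc2n[nH]c3cc(O)c(C(=O)N(C)Cc4ccc(F)c(F)c4)cc23)c1` differs from compound 2 by 3,4-difluorophenyl in place of 4-methoxyphenyl on a saturated chain carbon bound to an amide-type nitrogen. Among the measured compounds shown here, the one measured step that bears on this change is a 1.1-fold higher number from compound 1 to compound 2 (0.04 log units; within the scatter): adding the methoxy to the benzyl group moved the number by an amount within the scatter. For the measured compounds named here, no measured step covers fluorine on that group, so the difluoro part of the change is without precedent here. The step from compound 2 to compound 3 is therefore expected to stay within the scatter, a 1.1-fold lower number from compound 2 to compound 3 (0.03 log units; within the scatter). For compound 3 in this assay the estimate is 500 nM, with a range of 220 nM to 1100 nM.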

Compound 3, half-maximal inhibitory concentration: 530 nM
For compound 3 the middle estimate is 1.1-fold (0.03 log units) below the measured one; low and high end bracket the measured number.
By their numbers in this assay, from the lowest: compounds 1, 3 and 2 (each within the scatter of the next).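

In this assay the 3,4-difluorobenzyl group takes the place of 4-methoxybenzyl with a 1.0-fold lower number from compound 2 to compound 3 (0.01 log units; within the scatter) and takes the place of the unsubstituted benzyl group with a 1.1-fold higher number from compound 1 to compound 3 (0.03 log units; within the scatter) and so all three compounds remain unordered. Fluorine on the benzyl group, absent from compound 1 and compound 2, now joins methoxy as a second kind of substitution at this position that stays within the scatter. No supporting measurement accounts for how closely the three numbers agree.

From the compounds shown here alone, whether this holds for a ring carrying a carboxylic acid or an aminomethyl group, or for a longer chain in place of the benzyl group, stays open. Only this one part of the structure varies here, so the compounds shown say nothing about the rest of the molecule.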